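Cytotoxicity of a sulfonamide analogue in the shared core

The compounds below may be only part of what the source reports. "The series", "measured", "known", "first", "only" and "open" are said of these compounds alone.

Of the compounds shown here, three sharing one core have been tested in a functional assay on HEK293 cells (Homo sapiens) for cytotoxicity; a lower number here means that less compound is tolerated, a higher number that more compound is tolerated. Compound 1 `COc1ccc([C@H]2CC(=O)N(c3cc(N)cc(N)c3)C2)cc1OC1CCCC1` carries a 3,5-diaminophenyl group on the amide-type nitrogen in the ring; in this assay compound 1 gives only a limit, > 10000 nM. Compound 2 `COc1ccc([C@H]2CC(=O)N(c3cccc([S+](C)[O-])c3)C2)cc1OC1CCCC1` also gives only a limit in this assay, > 10000 nM. Compound 3 `COc1ccc([C@H]2CC(=O)N(c3ccc(S(C)(=O)=O)cc3)C2)cc1OC1CCCC1`, with 4-(methylsulfonyl)phenyl on the same nitrogen, gives a limit too, > 10000 nM. Because (the limit of > 10000 nM in this assay, at which 3 of the 3 values shown sit), the steps a step that the two limits leave unreadable from compound 1 to compound 2, a step that the two limits leave unreadable from compound 1 to compound 3 and a step that the two limits leave unreadable from compound 2 to compound 3 cannot be read, and compound 2 stands where every measured compound stands, at the limit.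

Compound 4 `COc1ccc([C@H]2CC(=O)N(c3cccc(NS(=O)(=O)c4cccc(Cl)c4)c3)C2)cc1OC1CCCC1` is not yet measured. It differs from compound 2 by a group of 11 heavy atoms (6 carbon, 1 nitrogen, 2 oxygen, 1 sulfur, 1 chlorine; one six-membered aromatic ring of carbon only) in place of a group of 3 heavy atoms (1 carbon, 1 oxygen, 1 sulfur; no ring), on an aromatic carbon. Among the measured compounds shown here, no measured step resembles this change, so the only guide is that none of the three compounds reached a readable concentration. Compound 4 is therefore expected to give 10000 nM in this assay, in the range 3000 nM to 30000 nM. This estimated step a number no higher from compound 2 to compound 4 (the limit leaves the size open) is not expected to stand out beyond the scatter.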

Compound 4, half-maximal cytotoxic concentration: > 10000 nM
Compound 4 gave a limit, no number; the forecaster's own chance of this, stated with the estimate: 65%; the middle value sits exactly at the limit.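

The step from compound 2 to compound 4 cannot be read, since both compounds give only a limit in this assay: the limit of > 10000 nM in this assay, at which 4 of the 4 values shown sit.

The compounds shown leave open what number any of them would give in this assay, and so whether the ((3-chlorophenyl)sulfonyl)amino group makes any difference there.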